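Thiophene in place of the dimethylaminophenyl arm

A few compounds are considered here, and "the series" means these few. Any claim that something is new, unique, unknown or untested is made for them only; others in the source may bear on it.

Measured so far in a functional assay on MKN-45 cells (Homo sapiens) for cytotoxicity, read by MTT assay, with a stated time of 72 h; a lower number here means a stronger inhibitor, a higher number a weaker inhibitor:
- Compound 1, `COc1cc2c(Oc3ccc(NC(=O)N/N=C/c4ccc(OC(F)(F)F)cc4)cc3F)ccnc2cc1OCCCN1CCCCC1`, gives 630 nM.
- Compound 2, `COc1ccc(/C=N/NC(=O)Nc2ccc(Oc3ccnc4cc(OCCCN5CCCCC5)c(OC)cc34)c(F)c2)c(OC)c1`, gives 1990 nM.
- Compound 3, `COc1cc2c(Oc3ccc(NC(=O)N/N=C/c4ccc(N(C)C)cc4)cc3F)ccnc2cc1OCCCN1CCCCC1`, gives 870 nM.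

Among these three numbers compound 3 stands second highest; it lies within the scatter of compound 1, as a 1.4-fold higher number from compound 1 to compound 3 (0.14 log units; within the scatter) shows, and apart from compound 2, as a 2.3-fold lower number from compound 2 to compound 3 (0.36 log units; beyond the scatter) shows. The unmeasured compound 4, `COc1cc2c(Oc3ccc(NC(=O)N/N=C/c4cccs4)cc3F)ccnc2cc1OCCCN1CCCCC1`, differs from compound 3 in one place: thiophen-2-yl in place of 4-(dimethylamino)phenyl on a carbon with a double bond to nitrogen. Within the data shown here, no measured step swaps a six-membered aromatic ring for a five-membered one, so the closest guides are the other exchanges on the same carbon. Those steps, a 3.2-fold higher number from compound 1 to compound 2 (0.50 log units; beyond the scatter) and a 2.3-fold lower number from compound 2 to compound 3 (0.36 log units; beyond the scatter), were modest, and a 1.4-fold higher number from compound 1 to compound 3 (0.14 log units; within the scatter) fell within the scatter; none of the three aryl variants moved the number far. On that basis the step of a 1.4-fold higher number from compound 3 to compound 4 (0.14 log units; within the scatter) is expected to be small, most likely toward a somewhat higher number, and it could fall within the scatter. Compound 4 is therefore estimated at 1200 nM in this assay, with a plausible range from 400 nM to 3600 nM.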

Compound 4, half-maximal inhibitory concentration: 740 nM
Compound 4: middle estimate off by 1.6-fold (0.21 log units), on the high side; measured number inside the range.
By their numbers in this assay, from the lowest: compounds 1, 4 and 3 (each within the scatter of the next); then compound 2.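

In this assay, the carbon with a double bond to nitrogen accepts a five-membered aromatic ring with 1 hetero atom in place of a six-membered aromatic ring of carbon only, with no step beyond the scatter: a 1.2-fold lower number from compound 3 to compound 4 (0.07 log units; within the scatter) and a 1.2-fold higher number from compound 1 to compound 4 (0.07 log units; within the scatter). Thiophen-2-yl, with 5 heavy atoms, thus cannot be told apart from 4-(dimethylamino)phenyl, with 9, or from 4-(trifluoromethoxy)phenyl, while the step of a 2.7-fold lower number from compound 2 to compound 4 (0.43 log units; beyond the scatter) leaves 2,4-dimethoxyphenyl as the one group of the four whose compound stands apart from each of the others. No measurement of any property of these groups accompanies the numbers, so the data offer no explanation for this pattern.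

The compounds shown leave open whether the same flat response holds for a saturated ring such as cyclohexyl, for a ring carrying nitrogen such as pyridin-3-yl, or for thiophen-3-yl, which is joined through the other ring carbon. They also leave open whether thiophen-2-yl would behave in the same way on a shared core with a morpholine in place of the piperidine at the end of the chain.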